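A Trifluoromethoxy Change at the Assay Limit

A few compounds are considered here, and "the series" means these few. Any claim that something is new, unique, unknown or untested is made for them only; others in the source may bear on it.

Going by the values given here, compound 1 (`Cc1ccc(NC(=O)Nc2cc(C)nc3ccccc23)cc1`) and compound 2 (`Cc1cc(NC(=O)Nc2ccc(O)cc2)c2ccccc2n1`) are the two measured members of this small series. In an ADME assay on HEK293 cells (Homo sapiens) for cytotoxicity, with a stated time of 72 h (a lower number here means that less compound is needed, a higher number that more compound is needed for the effect), compound 1 gives > 25000 nM as a limit of the assay and not a number. In this assay compound 2 gives > 25000 nM as a limit too. Compound 2 therefore has no number of its own, and the whole record is the limit of > 25000 nM in this assay, at which 2 of the 2 values shown sit, and nothing more. Among the compounds with values here, the single measured step, hydroxy in place of methyl on an aromatic carbon, reads a step that the two limits leave unreadable from compound 1 to compound 2 and so offers no size to carry forward.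

Compound 3 (`Cc1cc(NC(=O)Nc2ccc(OC(F)(F)F)cc2)c2ccccc2n1`) keeps the shared core and differs from compound 2 only at the hydroxy group. The difference is trifluoromethyl in place of hydrogen on an oxygen on an aromatic ring in all, trifluoromethyl in place of hydrogen on an oxygen on an aromatic ring. With no readable step to build on, no change beyond the scatter is expected in this assay and another limit is the likeliest report. The expected change is a number no higher from compound 2 to compound 3 (the limit leaves the size open) in size. Compound 3 is estimated at 25000 nM with an expected range from 9000 nM to 25000 nM for any number reported.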

Compound 3, half-maximal effective concentration: 14000 nM
Compound 3: middle estimate off by 1.8-fold (0.25 log units), on the high side; the measured number falls inside the stated range.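

With trifluoromethoxy in place of the hydroxy group, compound 3 gives 14000 nM in this assay, which makes it the first compound shown with a number and not a limit of the assay. This change reads as an at least 1.7-fold lower number from compound 2 to compound 3 (0.25 log units; that floor lies within the scatter), and the change from the methyl group of compound 1 reads as an at least 1.7-fold lower number from compound 1 to compound 3 (0.25 log units; that floor lies within the scatter). Both sizes are floors that stay within the scatter, so this position is now shown to allow a reading inside the assay's range, but neither change has yet been shown to have a real effect, and the step between the two compounds at the limit still cannot be read.

As far as these compounds go, how far compound 1 and compound 2 truly lie from compound 3 remains open, with a single number and the rest of the record resting on one limit: the limit of > 25000 nM in this assay, at which 2 of the 3 values shown sit. Also open is how an amine, a carboxylic acid or a methoxy group in this same place would read in this assay, and whether any of them would give a number or another limit.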